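A Methyl-to-Ethyl Step Toward Compound 4

This account rests on a few compounds, and the source may have more. Where it says the series, first, only, none or still open, it means among the compounds named here.

Compound 1, `CCOC(=O)C1=C(C)NC(C)=C(C(=O)OCC(C)C)C1c1csc(-c2ccc(Cl)cc2)n1`: 15400 nM
Compound 2, `CCOC(=O)C1=C(C)NC(C)=C(C(=O)OC2CCCCC2)C1c1csc(-c2ccc(Cl)cc2)n1`: 100000 nM
Compound 3, `COC(=O)C1=C(C)NC(C)=C(C(=O)OC(C)c2ccccc2)C1c1csc(-c2ccc(Cl)cc2)n1`: 7620 nM

In an assay on isolated protein for antagonist activity at Voltage-dependent L-type calcium channel subunit alpha-1C (Cavia porcellus), with a stated time of 15 min (a higher number here means a weaker inhibitor, a lower number a stronger inhibitor), compound 3 gives 7620 nM. Among the three measured compounds this is the lowest number, which here means the strongest inhibitor; compound 1 with 15400 nM stands nearest, and compound 2 with 100000 nM stands furthest away.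

Compound 4, `CCOC(=O)C1=C(C)NC(C)=C(C(=O)OC(C)c2ccccc2)C1c1csc(-c2ccc(Cl)cc2)n1`, differs from compound 3 in one place: methyl in place of hydrogen on a saturated chain carbon bound to an oxygen next to a carbonyl group. Within the data shown here, the only measured step that touches the same kind of position is a 6.5-fold higher number from compound 1 to compound 2 (0.81 log units; beyond the scatter); it shows that the group on an oxygen next to a carbonyl group can shift the result, but it concerns the other such oxygen of the shared core and exchanges two much larger groups. Among the measured compounds shown here, no measured pair isolates the exchange of methyl for ethyl at the oxygen that changes here, so nothing in the data points to a direction. The expectation is therefore a step that stays within the usual scatter, a 1.1-fold lower number from compound 3 to compound 4 (0.04 log units; within the scatter), with compound 4 landing close to compound 3. The estimate for compound 4 in this assay is 7000 nM, with a range from 2500 nM to 20000 nM.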

Compound 4, half-maximal inhibitory concentration: 13800 nM
Compound 4: middle estimate off by 2.0-fold (0.29 log units), on the low side, and the stated range covers the measured number.
By their numbers in this assay, from the lowest: compounds 3, 4 and 1 (each within the scatter of the next, the first and the last beyond it); then compound 2.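

In this assay, among these compounds, the change from methoxycarbonyl to ethoxycarbonyl gives a 1.8-fold higher number from compound 3 to compound 4 (0.26 log units; within the scatter), the first direct reading at this position, and it shows that methyl in place of hydrogen here does not move the result beyond the scatter. With compound 4 in hand, the group on the other oxygen next to a carbonyl group can also be compared with the ethoxycarbonyl group held fixed: 1-phenylethyl in place of cyclohexyl gives a 7.2-fold lower number from compound 2 to compound 4 (0.86 log units; beyond the scatter), whereas 1-phenylethyl in place of isobutyl gives a 1.1-fold lower number from compound 1 to compound 4 (0.05 log units; within the scatter), so among these three compounds only the cyclohexyl compound stands apart. There is no measured evidence that explains either the small step at the ethoxycarbonyl group or the larger one involving cyclohexyl.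

On these data alone, whether the result would stay equally unchanged with a longer chain, such as propyl or butyl, in place of ethyl remains open, since this single step covers only methyl and ethyl. As far as these compounds go, it is also open how a chain ending in an amine or a carboxylic acid would behave at this oxygen.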